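Compound 4: a substituted arm on the core of compound 3

The source may hold more compounds than are shown below. What is called first, only, known or untested is meant among the compounds shown, and "the series" means these compounds.

Of the compounds shown here, three have been measured in a functional assay (aorta) with Oryctolagus cuniculus as the target; a lower number here means a stronger inhibitor, a higher number a weaker inhibitor. Going by the values given here, compound 1 `OCc1ccc(-c2nn(Cc3ccc(F)cc3)c3ccccc23)o1` gives 19000 nM, and compound 2 `OCc1ccc(-c2nn(Cc3ccc(Cl)s3)c3ccccc23)o1` gives 7200 nM; the only single-place step, a 2.6-fold lower number from compound 1 to compound 2 (0.42 log units; beyond the scatter), concerns the group on the saturated chain carbon bound to an aromatic nitrogen. Compound 3 `Fc1ccccc1Cn1nc(-c2ncccn2)c2cccnc21` gives 1250 nM and stands lowest of the three, clearly apart from compound 2 and further still from compound 1. Compound 4 `Nc1nc(-c2nn(Cc3ccccc3F)c3ncccc23)ncc1F` differs from compound 3 at one place: 4-amino-5-fluoropyrimidin-2-yl in place of pyrimidin-2-yl on an aromatic carbon. Among the compounds with values here, the measured step sits at a different position and does not bear on this change, so no directly comparable pair guides the expectation; a modest move in either direction, or none beyond the scatter, is expected. Compound 4 is expected to give 800 nM, between 200 nM and 3000 nM, meaning an expected step of a 1.6-fold lower number from compound 3 to compound 4 (0.19 log units; within the scatter).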

Compound 4, half-maximal inhibitory concentration: 478000 nM
Beside the measured number, compound 4's estimate is 600-fold (2.78 log units) below it, outside the stated range (above it).
By their numbers in this assay, from the lowest: compound 3; then compound 2; then compound 1; then compound 4.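

In this assay, this position, an aromatic carbon of the five-membered aromatic ring, proves far from indifferent to what the arm carries: 4-amino-5-fluoropyrimidin-2-yl in place of pyrimidin-2-yl gives a 380-fold higher number from compound 3 to compound 4 (2.58 log units; beyond the scatter), a much larger step than the one seen earlier at the group on the saturated chain carbon. The ring of the arm stays a six-membered aromatic ring with two hetero atoms, so the substituents on it are enough to produce this loss of strength. No evidence here bears on the reason for it.

Going by these compounds, the amine and the fluorine enter together, so their separate contributions stay open. On these data alone, it also remains open how 4-aminopyrimidin-2-yl alone, 5-fluoropyrimidin-2-yl alone or a methyl on the pyrimidine would compare with pyrimidin-2-yl.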